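Chloro on the core of compound 3: working notes

A few compounds are considered here, and "the series" means these few. Any claim that something is new, unique, unknown or untested is made for them only; others in the source may bear on it.

In a functional assay on HeLa cells (Homo sapiens) for antiproliferative activity, read by sulforhodamine B assay, with a stated time of 72 h (on this read-out higher numbers stand for weaker inhibition and lower numbers for stronger inhibition), compound 1 (`FC(F)(F)c1cccc(/C=C\c2cc3ccccc3nc2Cl)c1`) gives 2850 nM, compound 2 (`COc1ccc2nc(Cl)c(/C=C\c3cc(C(F)(F)F)cc(C(F)(F)F)c3)cc2c1`) gives 4140 nM and compound 3 (`FC(F)(F)c1cc(/C=C\c2cc3ccccc3nc2Cl)cc(C(F)(F)F)c1`) gives 6780 nM. Compound 3 therefore shares the upper end of this small set with compound 2, the two lying within the scatter of each other, and stands clear of compound 1.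

The next structure is compound 4 (`FC(F)(F)c1cc(/C=C\c2cc3ccc(Cl)cc3nc2Cl)cc(C(F)(F)F)c1`). Its change from compound 3 is chloro in place of hydrogen on an aromatic carbon, in a six-membered aromatic ring of carbon only that is part of a fused or bridged system of two rings.

Within the data shown here, two measured steps bear on this. The first, with trifluoromethyl in place of hydrogen on an aromatic carbon, is modest: a 2.4-fold higher number from compound 1 to compound 3 (0.38 log units; beyond the scatter). The second, with hydrogen in place of methoxy on an aromatic carbon, stays within the scatter: a 1.6-fold higher number from compound 2 to compound 3 (0.21 log units; within the scatter). Among the measured compounds shown here, neither step involves chloro, and no measured compound carries chloro at this place, so the guidance is weak. Among these three compounds, single changes have moved the number little, so no step beyond the scatter is expected in this assay. The estimated step is a 1.4-fold lower number from compound 3 to compound 4 (0.13 log units; within the scatter). For compound 4 the expected value is 5000 nM, with an estimated range of 2000 nM to 12000 nM.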

Compound 4, half-maximal inhibitory concentration: 41400 nM
Estimate against measurement, compound 4: 8.3-fold (0.92 log units) below; the whole stated range lies below it.
By their numbers in this assay, from the lowest: compounds 1, 2 and 3 (each within the scatter of the next, the first and the last beyond it); then compound 4.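

In this assay, among these compounds, chloro in place of hydrogen on an aromatic carbon of the six-membered aromatic ring of carbon only gives a 6.1-fold higher number from compound 3 to compound 4 (0.79 log units; beyond the scatter), a move towards weaker inhibition and the first step that puts a group at this place. Among the compounds shown here, the one earlier change on this ring, involving methoxy at a different carbon, stayed small at a 1.6-fold higher number from compound 2 to compound 3 (0.21 log units; within the scatter), so the ring as a whole cannot be treated as indifferent to substitution: the outcome depends on the group, the carbon or both. For the compounds shown here, no measurement of any property accompanies these compounds, and the data offer no account of the step.

With chloro as the only group shown at this place, it remains open whether the loss belongs to chloro itself or to any group on this carbon, and fluoro, methyl or an amine there would help to separate the two. On these data alone, it is also open whether the same change would carry over to the core of compound 1, with its single trifluoromethyl, or to the methoxy-bearing core of compound 2.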